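A longer chain on compound 2

The compounds below may be only part of what the source reports. "The series", "measured", "known", "first", "only" and "open" are said of these compounds alone.

In a functional assay on A549 cells (Homo sapiens) for inhibition, read by sulforhodamine B assay, with a stated time of 72 h (on this read-out higher numbers stand for weaker inhibition and lower numbers for stronger inhibition), compound 1 `COc1cc2c(Nc3ccc(F)c(Cl)c3)ncnc2cc1OCCCn1ccnc1[N+](=O)[O-]` gives 4310 nM and compound 2 `COc1cc2c(Nc3ccc(OCc4cccc(F)c4)c(Cl)c3)ncnc2cc1OCCCn1ccnc1[N+](=O)[O-]` gives 1520 nM, the lower of the two numbers. Among the compounds with values here, the only measured step is a 2.8-fold lower number from compound 1 to compound 2 (0.45 log units; beyond the scatter), with (3-fluorobenzyl)oxy in place of fluoro on an aromatic carbon. Compound 3 `COc1cc2c(Nc3ccc(OCc4cccc(F)c4)c(Cl)c3)ncnc2cc1OCCCCCn1ccnc1[N+](=O)[O-]` differs from compound 2 in the chain alone: 2-(2-nitro-1H-imidazol-1-yl)ethyl in place of 2-nitro-1H-imidazol-1-yl on a saturated chain carbon, three bonds along the chain from an oxygen on an aromatic ring, on a saturated chain carbon, three bonds along the chain from an oxygen on an aromatic ring. The measured step involves a different part of the molecule, so it bears only indirectly on this change, as a sense of scale. It offers no direction, and no change beyond the scatter is expected in this assay. The expected step is a 1.0-fold lower number from compound 2 to compound 3 (0.01 log units; within the scatter). For compound 3 the estimated value is 1500 nM, with an expected range from 600 nM to 3800 nM.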

Compound 3, half-maximal inhibitory concentration: 14400 nM
For compound 3 the middle estimate is 9.6-fold (0.98 log units) below the measured one; the measured number lies above the stated range.
By their numbers in this assay, from the lowest: compound 2; then compound 1; then compound 3.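

Lengthening the chain was not neutral in this assay: 2-(2-nitro-1H-imidazol-1-yl)ethyl in place of 2-nitro-1H-imidazol-1-yl gave a 9.5-fold higher number from compound 2 to compound 3 (0.98 log units; beyond the scatter) and so weaker inhibition. Within the data shown here, the earlier step concerned a different part of the molecule, so this is the first sign that the read-out responds to a change on this saturated chain carbon, three bonds along the chain from an oxygen on an aromatic ring. Nothing presented here gives a measured reason for the change.

Among these compounds, a single lengthening gives a direction for only this pair, so it remains open whether a shorter chain would follow the same trend or whether the loss would recur on the fluoro compound. Also open, on these data alone, is how an amine such as morpholine would fare at the end of the chain in place of 2-nitro-1H-imidazol-1-yl.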